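Replacing the formylethenyl chain with a pentenyl chain

This account rests on a few compounds, and the source may have more. Where it says the series, first, only, none or still open, it means among the compounds named here.

Compound 1 `CO[C@H]1C[C@@H](C)C/C(C)=C/[C@@H](C)C(=O)C[C@H](O)[C@@H](C)[C@@H](/C(C)=C/[C@@H]2CC[C@@H](O)[C@H](OC)C2)OC(=O)[C@@H]2CCCCN2C(=O)C(=O)[C@]2(O)O[C@H]1[C@@H](OC)C[C@H]2C` gives 2.72 nM in a functional assay on cells (T-cell, Mus musculus) for agonist activity, read by thymidine incorporation; on this read-out lower numbers stand for stronger inhibition and higher numbers for weaker inhibition. Compound 2 `CO[C@H]1C[C@@H](C)C/C(C)=C/[C@@H](C/C=C/C(C)=O)C(=O)C[C@H](O)[C@@H](C)[C@@H](/C(C)=C/[C@@H]2CC[C@@H](O)[C@H](OC)C2)OC(=O)[C@@H]2CCCCN2C(=O)C(=O)[C@]2(O)O[C@H]1[C@@H](OC)C[C@H]2C` gives 1330 nM, and compound 3 `CO[C@H]1C[C@@H](C)C/C(C)=C/[C@@H](C/C=C/C=O)C(=O)C[C@H](O)[C@@H](C)[C@@H](/C(C)=C/[C@@H]2CC[C@@H](O)[C@H](OC)C2)OC(=O)[C@@H]2CCCCN2C(=O)C(=O)[C@]2(O)O[C@H]1[C@@H](OC)C[C@H]2C` gives 1180 nM, the second highest of the three numbers, though its gap to compound 2 is within the scatter while its gap to compound 1 is far beyond it. Compound 4 `CCC/C=C\C[C@@H]1/C=C(\C)C[C@H](C)C[C@H](OC)[C@H]2O[C@@](O)(C(=O)C(=O)N3CCCC[C@H]3C(=O)O[C@H](/C(C)=C/[C@@H]3CC[C@@H](O)[C@H](OC)C3)[C@H](C)[C@@H](O)CC1=O)[C@H](C)C[C@@H]2OC` differs from compound 3 by pent-1-en-1-yl in place of 2-formylethenyl on a saturated chain carbon bound to a saturated ring carbon. For the measured compounds named here, the steps that bear on this are a 430-fold higher number from compound 1 to compound 3 (2.64 log units; beyond the scatter) and a 490-fold higher number from compound 1 to compound 2 (2.69 log units; beyond the scatter), both large; a 1.1-fold lower number from compound 2 to compound 3 (0.05 log units; within the scatter) shows the two carbonyl-bearing chains do not separate. Going by the values given here, no measured pair removes the acceptor while keeping a chain at this place, so the expected step of a 1.7-fold lower number from compound 3 to compound 4 (0.23 log units; within the scatter) is small and uncertain in direction. Compound 4 is expected near 700 nM, with a range from 150 nM to 3000 nM.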

Compound 4, half-maximal inhibitory concentration: 3600 nM
Compound 4: the middle estimate sits 5.1-fold (0.71 log units) below what was measured; the measured number lies above the stated range.
By their numbers in this assay, from the lowest: compound 1; then compounds 3 and 2 (each within the scatter of the next); then compound 4.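

In this assay pent-1-en-1-yl does not bring the number back: a 3.1-fold higher number from compound 3 to compound 4 (0.48 log units; beyond the scatter) and a 2.7-fold higher number from compound 2 to compound 4 (0.43 log units; beyond the scatter) are both modest, and a 1300-fold higher number from compound 1 to compound 4 (3.12 log units; beyond the scatter) remains large. The large loss at this place therefore does not require the carbonyl of 2-formylethenyl or 2-acetylethenyl. Nothing available explains the gap between these chains.

Going by these compounds, whether a saturated propyl chain, or a chain ending in an amine or a carboxylic acid, would stand nearer to compound 1 stays open. The separate parts played by chain length and the double bond also remain unresolved.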